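Anilide series: aminomethyl for trifluoromethoxy on the benzamide ring

A few compounds are considered here, and "the series" means these few. Any claim that something is new, unique, unknown or untested is made for them only; others in the source may bear on it.

Of the compounds shown here, two have numbers so far. Compound 1 `COc1cc(OCC(=O)Nc2cccc(NC(=O)c3ccc(N(C)C)cc3)c2)ccc1C=O` gives 306 nM in an assay on isolated protein for inhibition of Rho-associated protein kinase 2 (Homo sapiens), read by scintillation counting, radiometric assay and 33P incorporation, with a stated time of 40 min, in the presence of a further agent that is not named here; a higher number here means a weaker inhibitor, a lower number a stronger inhibitor. Compound 2 `O=C(COc1ccc2c(=O)ccoc2c1)Nc1cccc(NC(=O)c2ccc(OC(F)(F)F)cc2)c1` gives 77 nM in the same assay, the lowest of the two numbers; the number of compound 1 stands higher, and the gap between them lies beyond the usual scatter. Among the measured compounds shown here, no pair of measured compounds differs in one place only, so no single change has yet been isolated.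

Compound 3 `NCc1ccc(C(=O)Nc2cccc(NC(=O)COc3ccc4c(=O)ccoc4c3)c2)cc1` has not been measured. It differs from compound 2 by aminomethyl in place of trifluoromethoxy on an aromatic carbon. For the measured compounds named here, with no comparable step on record, the expectation is a step of modest size, of uncertain direction, estimated at a 1.7-fold higher number from compound 2 to compound 3 (0.23 log units; within the scatter) and close to the scatter. Compound 3 is accordingly expected to give about 130 nM, with a plausible range from 35 nM to 500 nM.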

Compound 3, half-maximal inhibitory concentration: 66 nM
Compound 3: the middle estimate sits 2.0-fold (0.29 log units) above what was measured, within the range that was stated.
By their numbers in this assay, from the lowest: compounds 3 and 2 (each within the scatter of the next); then compound 1.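

In this assay, replacing trifluoromethoxy with aminomethyl on an aromatic carbon para to a large group gives a 1.2-fold lower number from compound 2 to compound 3 (0.07 log units; within the scatter), the first single change isolated in the series. The two compounds cannot be told apart here, although the substituents differ in size and composition: trifluoromethoxy has 5 heavy atoms and no hydrogen-bond donor, and aminomethyl has 2 heavy atoms and 1 hydrogen-bond donor. No measurement at hand accounts for this match.

From the compounds shown here alone, whether this position stays as insensitive with a carboxylic acid, or with a longer chain such as aminoethyl, remains open. Compound 1 differs from compound 2 in more than one place, so its number cannot be assigned to this position alone.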